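A few compounds are considered here, and "the series" means these few. Any claim that something is new, unique, unknown or untested is made for them only; others in the source may bear on it.

Compound 1 `O=C(/C=C/c1ccc(O)c(O)c1)N1CCN(c2ccccc2Cl)CC1`: 1.44 ug/mL
Compound 2 `COc1ccccc1N1CCN(C(=O)/C=C/c2ccc(O)c(O)c2)CC1`: 0.98 ug/mL

In a functional assay on A549 cells (Homo sapiens) for antiproliferative activity, read by MTT assay, with a stated time of 48 h (on this read-out higher numbers stand for weaker inhibition and lower numbers for stronger inhibition), compound 1 gives 1.44 ug/mL and compound 2 gives 0.98 ug/mL. These two numbers lie within the usual scatter of each other, so they set no real ranking. Compound 3 `COc1ccc(N2CCN(C(=O)/C=C/c3ccc(O)c(O)c3)CC2)cc1`, not yet measured, has 4-methoxyphenyl in place of 2-chlorophenyl on an amine nitrogen in a ring. The nearest evidence is compound 2, which has methoxy in place of chloro on an aromatic carbon, with a 1.5-fold lower number from compound 1 to compound 2 (0.17 log units; within the scatter). Within the data shown here, no measured compound carries 4-methoxyphenyl, so this guide is limited. No step beyond the scatter is therefore expected in this assay, and the estimated step is a 1.2-fold lower number from compound 1 to compound 3 (0.08 log units; within the scatter). The expected value for compound 3 is 1.2 ug/mL, with an estimated range of 0.5 ug/mL to 3 ug/mL.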

Compound 3, half-maximal inhibitory concentration: 0.93 ug/mL
Estimate against measurement, compound 3: 1.3-fold (0.11 log units) above; measured number inside the range.
By their numbers in this assay, from the lowest: compounds 3, 2 and 1 (each within the scatter of the next).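

In this assay, placing 4-methoxyphenyl on the amine nitrogen in a ring gives a 1.5-fold lower number from compound 1 to compound 3 (0.19 log units; within the scatter) and, against the 2-methoxyphenyl group, gives a 1.1-fold lower number from compound 2 to compound 3 (0.02 log units; within the scatter) in the same assay. Both steps lie within the scatter, so the three groups cannot be told apart here, and neither the choice between chloro and methoxy nor the place of the methoxy has a readable effect. Nothing at hand explains this result. Going by these compounds, whether an amine or a carboxylic acid on this phenyl ring would give a step beyond the scatter stays open.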